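Moving the Methyl Around the Outer Phenyl Ring

The source may report more compounds than this note shows. Statements on the series, on what has been measured and on what is new or still open speak of the compounds shown alone.

Measured compounds:
Compound 1 `Fc1ccccc1Nc1nc2nonc2nc1NC1CCCCC1`: in an assay on mitochondria from L6 cells (Rattus norvegicus) for activation, with a stated time of 90 min (a higher number here means that more compound is needed for the effect, a lower number that less compound is needed), compound 1 gives 13400 nM.
Compound 2 `Cc1ccccc1Nc1nc2nonc2nc1Nc1ccccc1F`: in this assay compound 2 gives 1100 nM.

Both compounds share the same core, carrying a (2-fluorophenyl)amino group on one side and a second amino substituent on the other. Among the measured compounds shown here, the only measured step so far is a 12-fold lower number from compound 1 to compound 2 (1.09 log units; beyond the scatter), a large drop in the amount of compound needed. Compound 2 therefore stands at the lower of the two numbers, and its nearest neighbour, compound 1, sits well beyond the scatter from it.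

Compound 3 `Cc1ccc(Nc2nc3nonc3nc2Nc2ccccc2F)cc1` differs from compound 2 in a smaller way: 4-methylphenyl in place of 2-methylphenyl on a nitrogen on an aromatic ring. Unlike the earlier step, no measured pair here changes where the methyl sits on a phenyl ring, so there is no direct guide. For the measured compounds named here, the one known step concerned a ring replacing a non-aromatic group, not a shift of a methyl within the same ring. The expectation is therefore a step of a 1.3-fold higher number from compound 2 to compound 3 (0.10 log units; within the scatter), essentially within the scatter. Compound 3 is estimated at 1400 nM, with a range from 400 nM to 5000 nM.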

Compound 3, half-maximal effective concentration: 2100 nM
Compound 3: middle estimate off by 1.5-fold (0.18 log units), on the low side; measured number inside the range.
By their numbers in this assay, from the lowest: compounds 2 and 3 (each within the scatter of the next); then compound 1.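

Shifting the methyl from 2-methylphenyl to 4-methylphenyl on the same nitrogen gives a 1.9-fold higher number from compound 2 to compound 3 (0.28 log units; within the scatter) in this assay, so this measurement cannot tell the two placements apart. Among the compounds shown here, this is the first look at a change within the outer ring itself, and the atoms and counted features of the two groups stay the same, so only the way they are joined differs. The advantage over cyclohexyl also extends beyond a single methylphenyl group: alongside a 12-fold lower number from compound 1 to compound 2 (1.09 log units; beyond the scatter) there is now a 6.4-fold lower number from compound 1 to compound 3 (0.80 log units; beyond the scatter), and both steps lie beyond the scatter, while no available evidence explains why the number stays within the scatter when the methyl moves.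

Going by these compounds, two placements of one small group say little about the ring as a whole, and it remains open whether the methyl contributes at all, a question that plain phenyl on this nitrogen could answer. On these data alone, it also remains open how 3-methylphenyl would compare, and whether a different group on the ring, such as a methoxy group, an amine or a carboxylic acid, would respond to its placement in the same way.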